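The source may report more compounds than this note shows. Statements on the series, on what has been measured and on what is new or still open speak of the compounds shown alone.

Measured so far:
- compound 1 `C[C@H](O)[C@@H](C)/C=C/C1=CC2=C(Cl)C(=O)[C@](C)(O)[C@@H](O)[C@@H]2CO1`: 0.0671 nM
- compound 2 `C/C=C(\C)C(=O)C[C@H]1C2=COC(/C=C/[C@H](C)[C@@H](C)O)=CC2=C(Cl)C(=O)[C@@]1(C)O`: 0.0016 nM

In a functional assay on L1210 cells (Mus musculus) for cytotoxicity, read by MTT assay, with a stated time of 72 h (on this read-out lower numbers stand for stronger inhibition and higher numbers for weaker inhibition), compound 2 gives 0.0016 nM, the lowest of the two numbers; compound 1 gives 0.0671 nM, a gap beyond the scatter. Compound 3 `C/C=C(\C)C(=O)C[C@H]1C2=COC(/C=C/[C@@H](C)[C@@H](C)O)=CC2=C(Cl)C(=O)[C@@]1(C)O` has not been measured. Its relation to compound 2: the two compounds have the same atoms and bonds and differ only in configuration as drawn: 1 of 6 stereo elements differ; a stereocentre at a saturated chain carbon is drawn S in compound 2 and R in compound 3. Going by the values given here, no step between measured compounds is known, so the effect of inverting this stereocentre is untested. A modest loss is expected, possibly within the scatter, since the rest of the molecule is unchanged; the expected step of a 3.1-fold higher number from compound 2 to compound 3 (0.49 log units; beyond the scatter) is set accordingly. Compound 3 is estimated at 0.005 nM, within 0.0013 nM to 0.03 nM.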

Compound 3, half-maximal inhibitory concentration: 0.0019 nM
Beside the measured number, compound 3's estimate is 2.6-fold (0.42 log units) above it, within the range that was stated.
By their numbers in this assay, from the lowest: compounds 2 and 3 (each within the scatter of the next); then compound 1.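

Inverting the stereocentre at a saturated chain carbon gives, in this assay, a 1.2-fold higher number from compound 2 to compound 3 (0.07 log units; within the scatter), the first step in the series that can be read. On this read-out, the configuration at this carbon therefore makes no difference beyond the scatter, and nothing else changes in the pair: the fact that compounds 2 and 3 differ only in the configuration as drawn

Only this one inversion has been read at this carbon, so the result says nothing about changing the chain itself. As far as these compounds go, whether an amine or a carboxylic acid in place of the chain hydroxyl would shift the number remains open.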